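Propoxy to (3-hydroxypropyl)amino on the shared core

The source may report more compounds than this note shows. Statements on the series, on what has been measured and on what is new or still open speak of the compounds shown alone.

Measured in a functional assay on MCF7 cells (Homo sapiens) for cytotoxicity; a lower number here means a stronger inhibitor, a higher number a weaker inhibitor:
- compound 1 `CCC(CO)Nc1nc(NCc2ccccc2)c2nc(Br)n(C(C)C)c2n1`: 53000 nM
- compound 2 `CCC(CO)Nc1nc(NCc2ccccc2)c2nc([N+](=O)[O-])n(C(C)C)c2n1`: 117000 nM
- compound 3 `CCCOc1nc2c(NCc3ccccc3)nc(NC(CC)CO)nc2n1C(C)C`: 50000 nM

The three compounds differ only in the group on one aromatic carbon. The data show a 1.1-fold lower number from compound 1 to compound 3 (0.03 log units; within the scatter) and a 2.2-fold higher number from compound 1 to compound 2 (0.34 log units; beyond the scatter). Compound 3 and compound 1 therefore cannot be separated, and only compound 2 stands apart from them.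

Compound 4 `CCC(CO)Nc1nc(NCc2ccccc2)c2nc(NCCCO)n(C(C)C)c2n1` has (3-hydroxypropyl)amino in place of propoxy on an aromatic carbon. All three measured steps are exchanges on this carbon, and the largest of them is modest: a 2.3-fold lower number from compound 2 to compound 3 (0.37 log units; beyond the scatter). Within the data shown here, none of the measured compounds carries the entering group, so these steps give only a rough guide to the size of the change and none to its direction.

The expected step in this assay is a 1.2-fold higher number from compound 3 to compound 4 (0.08 log units; within the scatter), so no clear change is anticipated. The estimate for compound 4 is 60000 nM, with an expected range of 25000 nM to 130000 nM.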

Compound 4, half-maximal inhibitory concentration: 40000 nM
Compound 4: the middle estimate sits 1.5-fold (0.18 log units) above what was measured; measured number inside the range.
By their numbers in this assay, from the lowest: compounds 4, 3 and 1 (each within the scatter of the next); then compound 2.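

In this assay, replacing propoxy, which has no hydrogen-bond donors, with (3-hydroxypropyl)amino, which has two, gives a 1.3-fold lower number from compound 3 to compound 4 (0.10 log units; within the scatter). Replacing bromo gives a 1.3-fold lower number from compound 1 to compound 4 (0.12 log units; within the scatter), so compound 1, compound 3 and compound 4 cannot be separated. Among these compounds, replacing nitro gives a 2.9-fold lower number from compound 2 to compound 4 (0.47 log units; beyond the scatter), the largest step in this set, and compound 2 remains the only compound that stands apart from the others.

No supporting data are available to explain these results. From the compounds shown here alone, it remains open whether a carboxylic acid, a piperazine or a longer chain on this aromatic carbon would take the number beyond the scatter of compound 1, compound 3 and compound 4.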